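Replacing an Arylamino Group by Phenyl at a Carbonyl

The source may report more compounds than this note shows. Statements on the series, on what has been measured and on what is new or still open speak of the compounds shown alone.

Of the compounds shown here, two have been measured so far in a functional assay on OVCAR-5 cells (Homo sapiens) for inhibition, read by sulforhodamine B assay, with a stated time of 48 h; a higher number here means a weaker inhibitor of growth, a lower number a stronger inhibitor of growth. Compound 1 `O=C(Nc1cccc(-n2cc(-c3ccncc3)c(-c3ccc(Cl)c(O)c3)n2)c1)Nc1cc(C(F)(F)F)cc(C(F)(F)F)c1` gives 2030 nM in this assay. Compound 2 `COc1cc(-c2nn(-c3cccc(NC(=O)Nc4cccc(C(F)(F)F)c4)c3)cc2-c2ccncc2)ccc1Cl` gives 6450 nM in this assay, the higher of the two numbers; the gap to compound 1 lies beyond the scatter, so compound 2 is the weaker growth inhibitor of the pair. Compound 3 `COc1cc(-c2nn(-c3cccc(NC(=O)c4ccccc4)c3)cc2-c2ccncc2)ccc1Cl` has not yet been measured. It differs from compound 2 in a single place: phenyl in place of (3-(trifluoromethyl)phenyl)amino on a carbonyl carbon. The carbonyl carbon keeps its amide-type nitrogen neighbour, while the group that carried the one hydrogen-bond donor is replaced by a plain phenyl. Among the measured compounds shown here, no step between two measured compounds matches this change, so the numbers offer no direct precedent. Because compound 2 already gives 6450 nM and stands at the weak end of the pair, the expectation is that the number rises further, in a step beyond the scatter. The expected step amounts to a 2.5-fold higher number from compound 2 to compound 3 (0.39 log units; beyond the scatter). For compound 3 the estimated value in this assay is 16000 nM, with a range from 5000 nM to 50000 nM.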

Compound 3, concentration for total growth inhibition: > 100000 nM
Compound 3 ended at the assay's limit; the forecaster's own chance of this, stated with the estimate: 15%; middle value at least 6.2-fold (0.79 log units) from the limit.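

In this assay, among the compounds shown here, the change at the carbonyl carbon gives an at least 15-fold higher number from compound 2 to compound 3 (1.19 log units; beyond the scatter) and is the first step between measured compounds that differ in one place, so it is the first direct reading of this position. It shows that this position is far from indifferent to what sits on the carbonyl carbon: with the amide-type nitrogen kept, phenyl in place of (3-(trifluoromethyl)phenyl)amino takes growth inhibition from a measurable number in compound 2 to the end of the measurable range, a loss that compounds 1 and 2, which both keep an arylamino group here, could not reveal. On these data alone, compound 3 stands at a limit of the assay and not at a number, so the true size of the step stays unknown: the limit of > 100000 nM in this assay, at which 1 of the 3 values shown sits.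

The change removes the amino nitrogen, with its hydrogen-bond donor, and the trifluoromethyl group together, and the compounds shown do not separate the two. A plain phenylamino group or a 3-(trifluoromethyl)phenyl group on the same carbonyl carbon would tell which of them carries the loss.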